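This account rests on a few compounds, and the source may have more. Where it says the series, first, only, none or still open, it means among the compounds named here.

Three esters of the shared core have been run in an assay on isolated protein for inhibition of squalene monooxygenase (Rattus norvegicus); a lower number here means a stronger inhibitor, a higher number a weaker inhibitor. Compound 1 `O=C(OCCCCc1ccccc1)c1cc(O)c(O)c(O)c1` gives 61300 nM. Compound 2 `O=C(OCCCCCCc1ccccc1)c1cc(O)c(O)c(O)c1` gives 11900 nM, and compound 3 `O=C(OCCCCCCCCc1ccccc1)c1cc(O)c(O)c(O)c1` gives 12500 nM. The step of a 5.2-fold lower number from compound 1 to compound 2 (0.71 log units; beyond the scatter) is the only move beyond the scatter seen so far; the next step, a 1.1-fold higher number from compound 2 to compound 3 (0.02 log units; within the scatter), is flat. Compound 3 thus stands second highest of the three numbers, indistinguishable from compound 2 and separated only from compound 1.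

Compound 4 `O=C(OCCCCCCCCCCc1ccccc1)c1cc(O)c(O)c(O)c1` extends the same chain once more: phenethyl in place of phenyl on a saturated chain carbon, eight bonds along the chain from an oxygen next to a carbonyl group. Both measured steps bear on it directly, as each is the same exchange of phenethyl for phenyl made at an earlier point of the same chain. The first was a modest drop, the second nothing; there is no sign that the gain from compound 1 to compound 2 continues, and the flat step from compound 2 to compound 3 is the closer precedent. The expected step of a 1.1-fold higher number from compound 3 to compound 4 (0.05 log units; within the scatter) is therefore one within the scatter, with a slight lean toward a higher number. For compound 4 in this assay the estimate is 14000 nM, within a range of 6000 nM to 35000 nM.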

Compound 4, half-maximal inhibitory concentration: 15300 nM
Estimate against measurement, compound 4: 1.1-fold (0.04 log units) below; measured number inside the range.
By their numbers in this assay, from the lowest: compounds 2, 3 and 4 (each within the scatter of the next); then compound 1.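

In this assay, phenethyl in place of phenyl on a saturated chain carbon, eight bonds along the chain from an oxygen next to a carbonyl group, gives a 1.2-fold higher number from compound 3 to compound 4 (0.09 log units; within the scatter), a second flat step in a row at the long end of the chain. Compounds 2, 3 and 4 now each lie within the scatter of the next, so the flat step from compound 2 to compound 3 is no longer a lone reading, and only compound 1 stands apart from this group. The same exchange therefore does not carry the same size at each place along the chain, and its effect in this series depends on where it is made: the same change on two cores in this assay, a 5.2-fold lower number (0.71 log units; beyond the scatter) from compound 1 to compound 2 and a 1.2-fold higher number (0.09 log units; within the scatter) from compound 3 to compound 4, 6.3-fold (0.80 log units) apart, beyond the scatter of two such steps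

Still open, as far as these compounds go, is whether a longer chain than that of compound 4 would stay level with compounds 2, 3 and 4 or move away from them, and whether this level depends on the phenyl at the chain end, which a cyclohexyl group or a carboxylic acid there would test. Also open, from the compounds shown here alone, is how the series would read with an amide in place of the ester on the shared core.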